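Anilino-quinazolinone-free note: acrylamide series, compound 2 to 3

The source may hold more compounds than are shown below. What is called first, only, known or untested is meant among the compounds shown, and "the series" means these compounds.

Hmm — that title names a ring; replace:

Working notes on the aryl swap from compound 2 to 3

For the measured compounds named here, the series so far holds two measured members. Compound 1 `O=C(CSc1nc(Nc2ccccc2)c2ccccc2n1)Nc1ccc(Cl)cc1Cl` is one; in a functional assay on PC-3 cells (Homo sapiens) for inhibition, read by MTT assay, with a stated time of 72 h (on this read-out higher numbers stand for weaker inhibition and lower numbers for stronger inhibition), compound 1 gives 9110 nM. Compound 2 `C=CC(=O)Nc1cccc(NC(=O)CSc2nc(Nc3ccccc3C)c3ccccc3n2)c1` carries the acrylamide-bearing aryl amide; in this assay compound 2 gives 23200 nM, the highest of the two numbers shown, and the nearest number, that of compound 1, lies beyond the scatter below it. Going by the values given here, compound 1 and compound 2 differ in more than one place, so no single step between them can be read off.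

Compound 3 `C=CC(=O)Nc1cccc(NC(=O)CSc2nc(Nc3ccc(Cl)cc3)c3ccccc3n2)c1` has not been measured. It differs from compound 2 by 4-chlorophenyl in place of 2-methylphenyl on a nitrogen on an aromatic ring. Among the compounds with values here, no measured pair covers this change alone, so the expectation rests only on the spread between compound 1 and compound 2 and on the change itself. The step expected from compound 2 to compound 3 is estimated as a 1.5-fold lower number from compound 2 to compound 3 (0.19 log units; within the scatter), small and towards a lower number, but close to the scatter. On that basis compound 3 is expected to give about 15000 nM in this assay, with a range from 5000 nM to 45000 nM.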

Compound 3, half-maximal inhibitory concentration: 10800 nM
Beside the measured number, compound 3's estimate is 1.4-fold (0.14 log units) above it; low and high end bracket the measured number.
By their numbers in this assay, from the lowest: compounds 1 and 3 (each within the scatter of the next); then compound 2.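

In this assay, for the compounds shown here, the change from 2-methylphenyl to (4-chlorophenyl) on a nitrogen on an aromatic ring gives a 2.1-fold lower number from compound 2 to compound 3 (0.33 log units; beyond the scatter) and is the first step that can be read at a single place, showing that the number moves with the aryl group held at this position, modestly but beyond the scatter. The two groups have the same count of heavy atoms, the same single six-membered aromatic ring of carbon only, no hydrogen-bond donors or acceptors and no net charge, so none of these counted features separates them, and the step can be tied only to the swap as a whole. Nothing available here bears on why the number moves.

Going by these compounds, it remains open whether the step follows the arrival of the chlorine, the departure of the methyl group or the place of the group on the ring; 4-methylphenyl or 2-chlorophenyl on the same nitrogen would separate these. Also open, on these data alone, is how an amine or a carboxylic acid on this ring would read in this assay and whether the same swap gives a similar step with the amide of compound 1 in place of the acrylamide-bearing one.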